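Methyl to cyclopropyl on the ring nitrogen

The source may hold more compounds than are shown below. What is called first, only, known or untested is meant among the compounds shown, and "the series" means these compounds.

Three measured compounds share one core and differ only in the group on an aromatic carbon. Compound 1 `Cn1nc(CN2CCCC2)nc1-c1ccc(C2(C(F)(F)F)CC2)cc1` carries 1-(trifluoromethyl)cyclopropyl, and in an assay on membranes from Jurkat cells for displacement of a labelled ligand from Sigma non-opioid intracellular receptor 1 (Homo sapiens), read by scintillation counting, with a stated time of 2 h (on this read-out higher numbers stand for weaker inhibition and lower numbers for stronger inhibition), compound 1 gives 9.9 nM. Compound 2 `Cn1nc(CN2CCCC2)nc1-c1ccc(C2CCCCC2)cc1` carries cyclohexyl; in this assay compound 2 gives 20 nM. Compound 3 `Cn1nc(CN2CCCC2)nc1-c1ccc(C(C)(C)C)cc1` carries tert-butyl; in this assay compound 3 gives 7.5 nM. Compound 3 stands at the lowest number shown, but its separation from compound 1 is within the scatter, so the two cannot be ordered; against compound 2 there is a clear step, a 2.7-fold lower number from compound 2 to compound 3 (0.43 log units; beyond the scatter), and a 2.0-fold higher number from compound 1 to compound 2 (0.31 log units; beyond the scatter) together with a 1.3-fold lower number from compound 1 to compound 3 (0.12 log units; within the scatter) complete the picture: the whole spread across the three is modest.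

Compound 4 `CC(C)(C)c1ccc(-c2nc(CN3CCCC3)nn2C2CC2)cc1` keeps the tert-butyl of compound 3 and alters the core instead: cyclopropyl in place of methyl on an aromatic nitrogen. Within the data shown here, no measured step touches this position; all three measured steps concern the group on the aromatic carbon, and even there the largest was modest. The data therefore give no basis for expecting a step beyond the scatter in this assay. The expected step is a 1.3-fold higher number from compound 3 to compound 4 (0.12 log units; within the scatter). Compound 4 is estimated at 10 nM, with a range from 3 nM to 35 nM.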

Compound 4, inhibition constant: 14 nM
For compound 4 the middle estimate is 1.4-fold (0.15 log units) below the measured one; measured number inside the range.
By their numbers in this assay, from the lowest: compounds 3, 1, 4 and 2 (each within the scatter of the next, the first and the last beyond it).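

Among these compounds, on the aromatic nitrogen, cyclopropyl in place of methyl gives a 1.9-fold higher number from compound 3 to compound 4 (0.27 log units; within the scatter) in this assay, the first reading at this position. The position therefore takes a three-membered non-aromatic ring of carbon only where methyl stood, with tert-butyl held constant and no step beyond the scatter, so the two groups cannot be separated here. No accompanying data bear on the origin of this result.

Going by these compounds, it remains open whether the position stays as flat with a hydrogen, a longer chain such as n-butyl, a benzyl group, or a substituent carrying an amine or a carboxylic acid. Also open, on these data alone, is whether cyclopropyl in place of methyl gives a similar step with cyclohexyl or 1-(trifluoromethyl)cyclopropyl on the aromatic carbon: this change has been read against tert-butyl only.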